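The source may report more compounds than this note shows. Statements on the series, on what has been measured and on what is new or still open speak of the compounds shown alone.

Compound 1 `Cc1ccc(C(=O)Nc2cccc(-c3oc4cc(-c5ccc(F)cc5)ccc4c(=O)c3O)c2)cc1` gives 2320 nM in a functional assay on HepG2 cells (Homo sapiens) for antiproliferative activity, read by CCK-8 assay, with a stated time of 72 h; on this read-out lower numbers stand for stronger inhibition and higher numbers for weaker inhibition. Compound 2 `O=C(Nc1cccc(-c2oc3cc(-c4ccc(F)cc4)ccc3c(=O)c2O)c1)c1ccc(Br)cc1F` is not resolved by this assay; for compound 2 only the limit > 100000 nM is reported. The step of an at least 43-fold higher number from compound 1 to compound 2 (1.63 log units; beyond the scatter) marks this loss, compound 2 resting at the limit of > 100000 nM in this assay, at which 1 of the 2 values shown sits. Compound 3 `COc1ccc(C(=O)Nc2cccc(-c3oc4cc(-c5ccc(F)cc5)ccc4c(=O)c3O)c2)c(F)c1` differs from compound 2 by methoxy in place of bromo on an aromatic carbon. Going by the values given here, no measured step covers this exchange alone; the single measured step changed two substituents at once, so it gives no clean guide to the methoxy-for-bromo swap. Compound 3 is therefore expected to stay near the limit, with an estimated step of an at least 2.5-fold lower number from compound 2 to compound 3 (0.39 log units; beyond the scatter). The estimate for compound 3 is 40000 nM, between 5000 nM and 100000 nM.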

Compound 3, half-maximal inhibitory concentration: 45300 nM
The estimate for compound 3 lay 1.1-fold (0.05 log units) below the measured number; the measured number falls inside the stated range.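

With the fluoro group kept, methoxy in place of bromo brings the series back to a resolved number: an at least 2.2-fold lower number from compound 2 to compound 3 (0.34 log units; beyond the scatter). On these data alone, compound 2 is reported only as a limit, so the true size of this step stays unknown: the limit of > 100000 nM in this assay, at which 1 of the 3 values shown sits. The 2-fluoro-4-methoxyphenyl group still falls well short of the 4-methylphenyl group: a 20-fold higher number from compound 1 to compound 3 (1.29 log units; beyond the scatter).

Open, as far as these compounds go, is how much of this loss belongs to the fluoro group and how much to the group on the aromatic carbon para to the large group, as both changes are joined in each step from compound 1. Also open, from the compounds shown here alone, is how an amine or a carboxylic acid would read at this place.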